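Swapping an Ether Chain for an Oxolane Ring

The source may report more compounds than this note shows. Statements on the series, on what has been measured and on what is new or still open speak of the compounds shown alone.

Compound 1 `Nc1ccc2cccc(OC3CCC3)c2n1`: > 2000 nM
Compound 2 `CCOCC(C)Oc1cccc2ccc(N)nc12`: 1070 nM

Both were tested in an assay on cells with melanin-concentrating hormone receptor 1 (Homo sapiens) as the target, read by radioligand binding; on this read-out higher numbers stand for weaker inhibition and lower numbers for stronger inhibition. For compound 1 the value > 2000 nM is a limit of the assay rather than a number. Compound 2, with 1070 nM, carries the only number shown. Within the data shown here, the single measured step, an at least 1.8-fold lower number from compound 1 to compound 2 (0.27 log units; that floor lies within the scatter), starts from that limit of > 2000 nM in this assay, at which 1 of the 2 values shown sits, and so gives only a weak hint. Compound 3 `Nc1ccc2cccc(OCC3CCOC3)c2n1` differs from compound 2 by a group of 6 heavy atoms (5 carbon, 1 oxygen; one five-membered non-aromatic ring with 1 hetero atom) in place of a group of 6 heavy atoms (5 carbon, 1 oxygen; no ring), on an oxygen on an aromatic ring. With the ether oxygen kept and the atom count unchanged, no step beyond the scatter is expected, so the change a 1.1-fold higher number from compound 2 to compound 3 (0.05 log units; within the scatter) in this assay is estimated near zero. Compound 3 is expected to give about 1200 nM, between 450 nM and 3000 nM.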

Compound 3, half-maximal inhibitory concentration: 115 nM
For compound 3 the middle estimate is 10-fold (1.02 log units) above the measured one; the measured number lies below the stated range.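

In this assay, matching heavy-atom counts and an oxygen in both groups did not make the two groups interchangeable on the oxygen on the aromatic ring: (oxolan-3-yl)methyl in place of the open chain gives a 9.3-fold lower number from compound 2 to compound 3 (0.97 log units; beyond the scatter). Putting it in place of cyclobutyl, a ring of carbon only, gives an at least 17-fold lower number from compound 1 to compound 3 (1.24 log units; beyond the scatter). The value of compound 1 is a limit, so that second step is only a floor: the limit of > 2000 nM in this assay, at which 1 of the 3 values shown sits.

Still open, going by these compounds, is whether the ring oxygen itself matters, or whether a cyclopentylmethyl group or a ring amine such as pyrrolidin-3-ylmethyl would serve equally well.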